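The compounds below may be only part of what the source reports. "The series", "measured", "known", "first", "only" and "open" are said of these compounds alone.

Compound 1 `CC(C)NC(=O)N1CCN(C(=S)SCc2cn(Cc3ccc(Cl)cc3)nn2)CC1`: > 128000 nM
Compound 2 `CCNC(=O)N1CCN(C(=S)SCc2cn(Cc3ccc(C)cc3)nn2)CC1`: > 128000 nM

Both compounds were tested in a functional assay on SMMC-7721 cells (Homo sapiens) for cytotoxicity, read by MTT assay, with a stated time of 72 h; on this read-out higher numbers stand for weaker inhibition and lower numbers for stronger inhibition. For compound 1 the value > 128000 nM is a limit of the assay, not a measured number. For compound 2 the value > 128000 nM is likewise only a limit. Compound 2 therefore has no exact figure to stand on, and nothing in these two points sets it apart from the other compound shown, as the limit of > 128000 nM in this assay, at which 2 of the 2 values shown sit, makes plain.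

Compound 3 `Cc1ccc(Cn2cc(CSC(=S)N3CCN(C(=O)NC(C)C)CC3)nn2)cc1` has not yet been tested. It differs from compound 2 in one place: methyl in place of hydrogen on a saturated chain carbon bound to an amide-type nitrogen and a saturated chain carbon. Going by the values given here, no pair of measured compounds shows the effect of such a change, so there is no measured step to lean on.

Because the limit of > 128000 nM in this assay, at which 2 of the 2 values shown sit, holds for both values shown, no shift beyond the usual scatter is expected from this change. The step from compound 2 to compound 3 is expected to be a step that the limit leaves unreadable from compound 2 to compound 3. Compound 3 is accordingly estimated at 150000 nM, within a range from 60000 nM to 400000 nM, and is most likely to be reported again only as a limit.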

Compound 3, half-maximal inhibitory concentration: > 128000 nM
Compound 3: no number, only a limit; the forecaster's own chance of this, stated with the estimate: 85%; the middle value lies beyond the limit too.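

No step can be read from compound 2 to compound 3 or from compound 1 to compound 3, since compounds 1, 2 and 3 all stop at the same limit: the limit of > 128000 nM in this assay, at which 3 of the 3 values shown sit. The compounds shown leave open whether changing ethylamino to isopropylamino, or chloro to methyl, alters the read-out at all, and what exact figure any of the three would reach.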